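Working notes: side-chain homologation read across two cores

The source may report more compounds than this note shows. Statements on the series, on what has been measured and on what is new or still open speak of the compounds shown alone.

Measured so far:
compound 1 `CC(C)=CC(=O)Nc1cccc(Oc2nc(Nc3ccn(C)n3)nc3c2CSCC3)c1` — > 50000 nM
compound 2 `CC(C)/C=C/C(=O)Nc1cccc(Oc2nc(Nc3ccn(C)n3)nc3c2CSCC3)c1` — > 50000 nM
compound 3 `CC(C)=CC(=O)Nc1cccc(Oc2nc(Nc3cccc(C#N)c3)nc3c2CSCC3)c1` — > 50000 nM

In a functional assay on MCF7 cells (Homo sapiens) for antiproliferative activity, read by MTT assay, with a stated time of 72 h (on this read-out lower numbers stand for stronger inhibition and higher numbers for weaker inhibition), compound 1 reaches only > 50000 nM, which is a limit of the assay and not a number. Compound 2 likewise stops at the limit > 50000 nM. Compound 3 also sits at the limit > 50000 nM. The change from compound 1 to compound 2 is 3-methylbut-1-en-1-yl in place of 2-methylprop-1-en-1-yl on a carbonyl carbon, and the step it made, a step that the two limits leave unreadable from compound 1 to compound 2, cannot be read because of the limit of > 50000 nM in this assay, at which 3 of the 3 values shown sit. The two cores differ by 3-cyanophenyl in place of 1-methyl-1H-pyrazol-3-yl on a nitrogen on an aromatic ring; the step that the two limits leave unreadable from compound 1 to compound 3 is equally unreadable. Compound 4 `CC(C)/C=C/C(=O)Nc1cccc(Oc2nc(Nc3cccc(C#N)c3)nc3c2CSCC3)c1` is not yet measured; it carries the same change as before, (3-methylbut-1-en-1-yl in place of 2-methylprop-1-en-1-yl on a carbonyl carbon), made on the core of compound 3, and the place of the change is identical in both pairs. The step that the limit leaves unreadable from compound 3 to compound 4 from compound 3 to compound 4 is expected to be flat, since compound 3 stands at the limit > 50000 nM and compound 2 stays at the limit > 50000 nM. Compound 4 is therefore estimated at 60000 nM, most likely reported only as a limit, within 20000 nM to 200000 nM.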

Compound 4, half-maximal inhibitory concentration: 29600 nM
Beside the measured number, compound 4's estimate is 2.0-fold (0.31 log units) above it, within the range that was stated.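

In this assay, 3-methylbut-1-en-1-yl in place of 2-methylprop-1-en-1-yl on a carbonyl carbon gives an at least 1.6-fold lower number from compound 3 to compound 4 (0.22 log units; that floor lies within the scatter), and 3-cyanophenyl in place of 1-methyl-1H-pyrazol-3-yl on a nitrogen on an aromatic ring gives an at least 1.6-fold lower number from compound 2 to compound 4 (0.22 log units; that floor lies within the scatter). Both steps are floors within the scatter, so they show that compound 4 has a readable value in this assay, but they establish neither a true size nor a real difference from compound 3 or compound 2. The same side-chain change on the core of compound 1 and the other steps cannot be read, so whether the change carries from one core to the other stays undecided: the limit of > 50000 nM in this assay, at which 3 of the 4 values shown sit.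

The compounds shown leave open how the number responds to a longer chain, such as hept-1-en-1-yl, on the carbonyl carbon. They also leave open what an amine, such as dimethylamino, or a carboxylic acid in that side chain would give on either core.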